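Cyclopropyl to Isopropyl on an Alkynyl Ester Scaffold

The source may report more compounds than this note shows. Statements on the series, on what has been measured and on what is new or still open speak of the compounds shown alone.

Compound 1 `COC(=O)C#CC(O/C=C/C(=O)OC)C1CC1`: 250 nM
Compound 2 `CC1CCC(C(C)C)C(OC(=O)C#CC(O/C=C/C(=O)OC2CC(C)CCC2C(C)C)C(C)C)C1`: > 100000 nM

In a functional assay on HBL-100 cells (Homo sapiens) for antiproliferative activity, read by sulforhodamine B assay, with a stated time of 48 h (a higher number here means a weaker inhibitor of growth, a lower number a stronger inhibitor of growth), compound 1 gives 250 nM, the only number measured among these two. Compound 2 sits at a limit of the assay, (the limit of > 100000 nM in this assay, at which 1 of the 2 values shown sits), and so shows only > 100000 nM. Compound 3 `COC(=O)C#CC(O/C=C/C(=O)OC)C(C)C` differs from compound 1 by isopropyl in place of cyclopropyl on a saturated chain carbon bound to an oxygen on an unsaturated carbon and a triple-bonded carbon. Among the measured compounds shown here, no step between two measured compounds is available here. With the change confined to that group, the step from compound 1 to compound 3 is expected to lie within the scatter, and a 1.2-fold higher number from compound 1 to compound 3 (0.08 log units; within the scatter) is the estimated step. Compound 3 is therefore expected to give 300 nM, in the range 100 nM to 1000 nM.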

Compound 3, concentration for 50% growth inhibition: 450 nM
For compound 3 the middle estimate is 1.5-fold (0.18 log units) below the measured one; measured number inside the range.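

In this assay, isopropyl in place of cyclopropyl on this saturated chain carbon gives a 1.8-fold higher number from compound 1 to compound 3 (0.26 log units; within the scatter). The three-membered ring is therefore not required for growth inhibition at this level, and the open-chain group of the same heavy-atom count serves in its place. No measurement shown here offers a reason for this result.

Going by these compounds, it remains open whether a longer chain or an amine on this carbon would be tolerated as well. Also open, on these data alone, is whether a carboxylic acid in place of either ester of the core would preserve the activity.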